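Chloro on compound 2: a small expected step

The source may report more compounds than this note shows. Statements on the series, on what has been measured and on what is new or still open speak of the compounds shown alone.

In an ADME assay on Caco-2 cells (Homo sapiens) for permeability, in the apical to basolateral direction (on this read-out lower numbers stand for lower permeability and higher numbers for higher permeability), compound 2 `CC(C)COc1ccc(-c2cn(C)c3cc(C(=O)NS(C)(=O)=O)c(F)cc23)cn1` gives 61 nm/s, within the scatter of compound 1 `CC(C)COc1ncc(-c2cn(C)c3cc(C(=O)NS(=O)(=O)C4CC4)c(F)cc23)cc1Cl` at 34 nm/s. Compound 3 `CC(C)COc1ncc(-c2cn(C)c3cc(C(=O)NS(C)(=O)=O)c(F)cc23)cc1Cl` differs from compound 2 by chloro in place of hydrogen on an aromatic carbon, ortho to an isobutoxy group. Going by the values given here, no measured pair isolates this change. Among the compounds with values here, the only guide is compound 1, which also carries the chloro and gives 34 nm/s in this assay. The expected step is a 1.4-fold lower number from compound 2 to compound 3 (0.13 log units; within the scatter), a small one that stays within the scatter. For compound 3 the estimated permeability is 45 nm/s, with an expected range of 20 nm/s to 95 nm/s.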

Compound 3, apparent permeability: 20 nm/s
For compound 3 the middle estimate is 2.3-fold (0.35 log units) above the measured one; low and high end bracket the measured number.
By their numbers in this assay, from the lowest: compounds 3, 1 and 2 (each within the scatter of the next, the first and the last beyond it).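

Chloro in place of hydrogen on an aromatic carbon, ortho to an isobutoxy group, now has a measured pair: in this assay the change gives a 3.1-fold lower number from compound 2 to compound 3 (0.48 log units; beyond the scatter) and so is a modest step beyond the scatter. Methyl in place of cyclopropyl on a sulfonyl sulfur, with the chloro kept, gives a 1.7-fold lower number from compound 1 to compound 3 (0.23 log units; within the scatter) and stays within the scatter, so only the chloro change stands clear of it. Going by these compounds, whether fluoro, methoxy or an amine at this position would give a similar step remains open. Nothing available here explains the chloro step.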